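This account rests on a few compounds, and the source may have more. Where it says the series, first, only, none or still open, it means among the compounds named here.

Measured compounds:
- compound 1 `CN1CCN(c2nc(/C=C/c3ccccc3)nc3ccsc23)CC1`: 198000 nM
- compound 2 `COc1ccc(Nc2nc(/C=C/c3cc(OC)c(OC)c(OC)c3)nc3ccsc23)cc1`: 279000 nM

In a functional assay on L02 cells (Homo sapiens) for inhibition, read by Griess assay, with stated times of 1 h and 24 h (on this read-out lower numbers stand for stronger inhibition and higher numbers for weaker inhibition), compound 1 gives 198000 nM. Compound 2 gives 279000 nM in this assay. Compound 2 has the higher of the two numbers, but its gap to compound 1 lies within the scatter, so the two cannot be told apart on these data.

The next compound to be measured is compound 3 `COc1cc(/C=C/c2nc(NCc3ccncc3)c3sccc3n2)cc(OC)c1OC`. It differs from compound 2 at a single place: (pyridin-4-yl)methyl in place of 4-methoxyphenyl on a nitrogen on an aromatic ring. Among the measured compounds shown here, no measured pair in this set covers such a change, so there is no step to lean on. With only the two values seen, both of them weak in this assay and not separable from each other, there is no ground for expecting a sizeable shift in either direction. The step from compound 2 is therefore expected to be small, most likely none beyond the scatter: a 1.1-fold lower number from compound 2 to compound 3 (0.05 log units; within the scatter). Compound 3 is expected to give about 250000 nM in this assay, with a range of 100000 nM to 600000 nM.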

Compound 3, half-maximal inhibitory concentration: 374000 nM
Compound 3: middle estimate off by 1.5-fold (0.17 log units), on the low side; measured number inside the range.
By their numbers in this assay, from the lowest: compounds 1, 2 and 3 (each within the scatter of the next).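

In this assay, putting (pyridin-4-yl)methyl in place of 4-methoxyphenyl on a nitrogen on an aromatic ring gives a 1.3-fold higher number from compound 2 to compound 3 (0.13 log units; within the scatter), the only single-place step among these compounds. Cut one bond further out, the same difference reads (4-methoxyphenyl)amino to ((pyridin-4-yl)methyl)amino, and it brings a six-membered aromatic ring with one hetero atom where a ring of carbon only stood. At this position, then, the exchange of these two groups leaves compound 3 not separable from compound 2 on this read-out, so the position now has one readable step, and that step lies within the scatter. No measurement bearing on why the step comes out this way is at hand.

Compound 1 differs from compound 2 and compound 3 in more than one place, so its steps to them cannot be read. As far as these compounds go, whether this position would stay as unresponsive with a morpholine, a carboxylic acid or a longer chain ending in a pyridine ring on that nitrogen remains open, as does whether any group there can bring the number down beyond the scatter.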